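Working notes on one aryl group exchange

The compounds below may be only part of what the source reports. "The series", "measured", "known", "first", "only" and "open" are said of these compounds alone.

In a physicochemical assay for lipophilicity, measured as octanol-water partition, at pH 7.4 (on this read-out lower numbers stand for lower lipophilicity and higher numbers for higher lipophilicity), compound 1 (`Cc1cccc(C)c1-c1cccc(COc2ccc3c(c2)CCCC3CC(=O)O)c1`) gives 4.7 and compound 2 (`Cc1cccc(C)c1-c1cccc(COc2ccc3c(c2)OCC3CC(=O)O)c1`) stands lower at 3.88 on these two numbers, a gap beyond the scatter. Compound 3 (`O=C(O)CC1COc2cc(OCc3cccc(-c4ccc5sccc5c4)c3)ccc21`) carries 1-benzothiophen-5-yl in place of 2,6-dimethylphenyl on an aromatic carbon, meta to a large group. Among the measured compounds shown here, no pair of measured compounds covers this exchange, so the estimate starts from compound 2 alone. In this assay the expected step (a number 0.07 log units higher from compound 2 to compound 3 (within the scatter)) stays within the scatter, with no firm direction. Compound 3 is estimated at 3.95 with an expected range of 3.5 to 4.4 on this read-out.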

Compound 3, distribution coefficient: 3.97
Beside the measured number, compound 3's estimate is 0.02 log units below it, within the range that was stated.
By their numbers in this assay, from the lowest: compounds 2 and 3 (each within the scatter of the next); then compound 1.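

On the shared core, 1-benzothiophen-5-yl in place of 2,6-dimethylphenyl, on an aromatic carbon meta to a large group, gives a number 0.09 log units higher from compound 2 to compound 3 (within the scatter) in this assay. Among the compounds shown here, compounds 1 and 2 both carry 2,6-dimethylphenyl here, so this is the first reading of a change at this position, and an added five-membered aromatic ring with one sulfur leaves the number within the scatter. Nothing available bears on the reason for this result.

From the compounds shown here alone, whether a group carrying an amine or a pyridine ring at this position would also stay within the scatter of compound 2 remains open. So does the size of the same exchange on the core of compound 1.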